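Aryl variation on an aromatic nitrogen: compound 3 to compound 4

The source may hold more compounds than are shown below. What is called first, only, known or untested is meant among the compounds shown, and "the series" means these compounds.

Measured in a functional assay on HCT-116 cells (Homo sapiens) for antiproliferative activity, read by MTT assay, with a stated time of 48 h; on this read-out lower numbers stand for stronger inhibition and higher numbers for weaker inhibition:

compound 1 `N#CC1=C(N)Oc2c(N)cc3nc4ccccc4nc3c2C12C(=O)N(Cc1cnnn1-c1ccc(F)cc1)c1ccccc12`: > 50000 nM, a limit of the assay rather than a number.
compound 2 `CCOc1ccccc1-n1nncc1CN1C(=O)C2(C(C#N)=C(N)Oc3c(N)cc4nc5ccccc5nc4c32)c2ccccc21`: > 50000 nM, likewise a limit.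
compound 3 `N#CC1=C(N)Oc2c(N)cc3nc4ccccc4nc3c2C12C(=O)N(Cc1cnnn1-c1cc(Cl)ccc1Cl)c1ccccc12`: > 50000 nM, likewise a limit.

All three measured compounds sit at the same limit (the limit of > 50000 nM in this assay, at which 3 of the 3 values shown sit), so none of the three aryl exchanges on the aromatic nitrogen can be read: a step that the two limits leave unreadable from compound 1 to compound 2, a step that the two limits leave unreadable from compound 1 to compound 3 and a step that the two limits leave unreadable from compound 2 to compound 3 are all unreadable. Compound 3 stands at the limit with the other two; no ranking among them is possible.

Compound 4 `N#CC1=C(N)Oc2c(N)cc3nc4ccccc4nc3c2C12C(=O)N(Cc1cnnn1-c1ccc([N+](=O)[O-])cc1[N+](=O)[O-])c1ccccc12` differs from compound 3 by 2,4-dinitrophenyl in place of 2,5-dichlorophenyl on an aromatic nitrogen. The three measured steps bear on this change only in that each exchange of the aryl group on the aromatic nitrogen left the value at the limit; their sizes are not readable. No readable step in this assay is therefore expected from the change to compound 4, and the value of compound 4 is expected most likely to remain a limit. Compound 4 is estimated at 60000 nM, with a range of 20000 nM to 200000 nM. The expected step that the limit leaves unreadable from compound 3 to compound 4 amounts to no change beyond the scatter.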

Compound 4, half-maximal inhibitory concentration: 23900 nM
Estimate against measurement, compound 4: 2.5-fold (0.40 log units) above, and the stated range covers the measured number.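

In this assay the aryl group on the aromatic nitrogen proves able to move the value off the limit: 2,4-dinitrophenyl gives an at least 2.0-fold lower number from compound 3 to compound 4 (0.32 log units; beyond the scatter) and an at least 2.0-fold lower number from compound 2 to compound 4 (0.32 log units; beyond the scatter) and an at least 2.0-fold lower number from compound 1 to compound 4 (0.32 log units; beyond the scatter) in this series. Among the compounds shown here, of the four aryl groups, only 2,4-dinitrophenyl carries nitro groups, so this exchange is the first with a readable direction. One side of each of these steps is a limit, which leaves their full size unknown, and compound 4 alone carries a number: the limit of > 50000 nM in this assay, at which 3 of the 4 values shown sit.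

From the compounds shown here alone, whether both nitro groups are needed for the step, or one alone would suffice, stays open. Also open, going by these compounds, is whether an amine or a carboxylic acid on the phenyl ring would leave the limit as well.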